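Adding an acetylsulfamoyl group to a pyrazole diphenol

The source may report more compounds than this note shows. Statements on the series, on what has been measured and on what is new or still open speak of the compounds shown alone.

Measured compounds:
compound 1, `COc1ccc(OC)c(-c2cc(-c3ccccc3)nn2-c2ccc(S(N)(=O)=O)cc2)c1`, 12300 nM
compound 2, `Oc1ccc(O)c(-c2cc(-c3ccccc3)nn2-c2ccccc2)c1`, 17100 nM
compound 3, `Oc1ccc(O)c(-c2cc(-c3ccc(Cl)cc3)nn2-c2ccccc2)c1`, 9250 nM

In a functional assay on cells (Cancer cell lines, Homo sapiens) for cytotoxicity, read by sulforhodamine B assay, with a stated time of 48 h (a higher number here means a weaker inhibitor of growth, a lower number a stronger inhibitor of growth), compound 2 gives 17100 nM, a number that lies within the usual scatter of both compound 1 and compound 3. Compound 4, `CC(=O)NS(=O)(=O)c1ccc(-n2nc(-c3ccccc3)cc2-c2cc(O)ccc2O)cc1`, differs from compound 2 by acetylsulfamoyl in place of hydrogen on an aromatic carbon. Going by the values given here, no measured pair shows exactly this change; compound 1 carries a sulfamoyl group on the same ring but also differs elsewhere, and its value and that of compound 2 sit within the scatter of each other. Among the compounds with values here, the one single-point step, a 1.8-fold lower number from compound 2 to compound 3 (0.27 log units; within the scatter), is also within the scatter. The step to compound 4 is therefore expected to stay within the scatter, a 1.2-fold lower number from compound 2 to compound 4 (0.09 log units; within the scatter). Compound 4 is estimated at 14000 nM, between 5000 nM and 40000 nM.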

Compound 4, concentration for 50% growth inhibition: 91300 nM
For compound 4 the middle estimate is 6.5-fold (0.81 log units) below the measured one; the measured number lies above the stated range.
By their numbers in this assay, from the lowest: compounds 3, 1 and 2 (each within the scatter of the next); then compound 4.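

In this assay, going by these compounds alone, acetylsulfamoyl at this place, para to a large group, gives a 5.3-fold higher number from compound 2 to compound 4 (0.73 log units; beyond the scatter), the only step here that lies beyond the scatter. This ring position therefore does respond to a change, and this change moves toward weaker inhibition of growth, whereas the chloro step stayed within the scatter. Nothing measured here explains this loss.

From the compounds shown here alone, whether an amine or a carboxylic acid at this place would also raise the number remains open. Also open, going by these compounds, is whether the acetyl part or the sulfamoyl part accounts for the step.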